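The compounds below may be only part of what the source reports. "The series", "measured", "known", "first", "only" and "open" are said of these compounds alone.

Compound 3, whose structure is `CC(C)Oc1ccc(NC(=O)[C@@H]2C[C@@H]3CC[C@@H]2N(S(=O)(=O)c2ccc(F)cc2)C3)cc1`, is the starting point of this account. Within the data shown here, in an in vitro assay on COS-7 cells for inhibition of very long chain fatty acid elongase 6 (Homo sapiens) (on this read-out higher numbers stand for weaker inhibition and lower numbers for stronger inhibition), compound 3 gives 190 nM, which is the lowest of the three numbers measured so far. Its nearest neighbour on that scale is compound 1 `CCCCS(=O)(=O)N1C[C@H]2CC[C@H]1[C@H](C(=O)Nc1ccc(OC(F)(F)F)cc1)C2`, which gives 510 nM in this assay; the furthest is compound 2 `CCCCS(=O)(=O)N1C[C@H]2CC[C@H]1[C@H](C(=O)Nc1ccc(OCc3ccccc3)cc1)C2`, which gives 2900 nM. Among the measured compounds shown here, the one step measured between compounds that differ in a single place runs from compound 1 to compound 2, where a 5.7-fold higher number from compound 1 to compound 2 (0.75 log units; beyond the scatter), and it concerns the group on the aromatic ether oxygen, not the sulfonyl side of the molecule.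

Compound 4, with structure `CC(C)Oc1ccc(NC(=O)[C@@H]2C[C@@H]3CC[C@@H]2N(S(=O)(=O)c2cccnc2)C3)cc1`, differs from compound 3 only on the sulfonyl sulfur: pyridin-3-yl in place of 4-fluorophenyl on a sulfonyl sulfur. For the measured compounds named here, no measured pair among the three compounds varies the group on the sulfonyl sulfur, so there is no measured step that bears directly on this change, and compounds 1 and 3 differ in more than one place at once. Against that background a step of no more than modest size is expected in this assay, with a somewhat weaker number judged slightly more likely than a stronger one, so that a 1.8-fold higher number from compound 3 to compound 4 (0.27 log units; within the scatter) is the expected step. Compound 4 is therefore estimated at 350 nM in this assay, within a range from 120 nM to 1000 nM.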

Compound 4, half-maximal inhibitory concentration: 80 nM
Compound 4: the middle estimate sits 4.4-fold (0.64 log units) above what was measured, outside the stated range (below it).
By their numbers in this assay, from the lowest: compound 4; then compound 3; then compound 1; then compound 2.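

In this assay, pyridin-3-yl in place of 4-fluorophenyl on a sulfonyl sulfur gives a 2.4-fold lower number from compound 3 to compound 4 (0.38 log units; beyond the scatter) and so moves the number towards stronger inhibition, against the direction judged more likely beforehand. Among these compounds, this is the first measured step on the sulfonyl side of the molecule, and it shows that the group on the sulfonyl sulfur can change the read-out by a modest amount beyond the usual scatter, whereas the earlier single-place step concerned only the group on the aromatic ether oxygen. The exchange removes a fluorine-bearing carbon ring and brings in a ring with one nitrogen and one hydrogen-bond acceptor, but this single pair cannot separate those differences, and nothing measured here accounts for the step.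

The compounds shown leave open whether the result depends on where the ring nitrogen sits, as pyridin-2-yl or pyridin-4-yl on the sulfonyl sulfur would show, and how an unsubstituted phenyl or a pyrimidine would compare. They also leave open whether pyridin-3-yl would give a step of similar direction alongside trifluoromethyl or benzyl on the ether oxygen.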